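The source may report more compounds than this note shows. Statements on the series, on what has been measured and on what is new or still open speak of the compounds shown alone.

In a functional assay on HepG2 cells (Homo sapiens) for cytotoxicity, read by MTT assay, with a stated time of 48 h (on this read-out lower numbers stand for stronger inhibition and higher numbers for weaker inhibition), compound 1 (`COc1ccc(/C=C/C(=O)/C=C/c2nc3ccccc3n2C)cc1O`) gives 2900 nM. Within the data shown here, this is the lower of the two numbers measured so far, and compound 2 (`COc1ccc(/C=C/C(=O)/C=C/c2nc3c(C)cccc3n2C)cc1O`) gives 14700 nM. Compound 3 (`COc1ccc(/C=C/C(=O)/C=C/c2nc3cc(Cl)ccc3n2C)cc1O`) has not yet been measured. It keeps the core of compound 1 and carries one change: chloro in place of hydrogen on an aromatic carbon. In words, chloro takes the place of hydrogen on an aromatic carbon of the six-membered aromatic ring of carbon only, which is part of a fused system of two rings.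

Among the measured compounds shown here, only one measured step bears on this change. Methyl in place of hydrogen on an aromatic carbon gave a 5.1-fold higher number from compound 1 to compound 2 (0.70 log units; beyond the scatter), a modest step that lies beyond the usual scatter. That step involves a different group, and a single example shows no trend, so it is only a loose guide. It suggests that adding a group to this ring may raise the number, though probably by less than that step. The expected change is a 1.6-fold higher number from compound 1 to compound 3 (0.19 log units; within the scatter), which means somewhat weaker inhibition. For compound 3 the estimated value is 4500 nM, with an expected range of 1500 nM to 13000 nM.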

Compound 3, half-maximal inhibitory concentration: 4100 nM
Estimate against measurement, compound 3: 1.1-fold (0.04 log units) above; the range from low to high includes it.
By their numbers in this assay, from the lowest: compounds 1 and 3 (each within the scatter of the next); then compound 2.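

In this assay chloro in place of hydrogen on an aromatic carbon gives a 1.4-fold higher number from compound 1 to compound 3 (0.15 log units; within the scatter) and so leaves the number at this carbon indistinguishable from that of the unsubstituted core. The earlier step, a 5.1-fold higher number from compound 1 to compound 2 (0.70 log units; beyond the scatter), had shown only that a methyl on this ring can go with a clear rise in the number; the new step shows that a group added to the same ring does not always do so, and that this carbon tolerates a chloro in this assay. Compounds 2 and 3 differ in both the group and the carbon that carries it, so these two steps cannot say whether the group or the place matters more, and nothing measured here explains the result.

Going by these compounds, it remains open whether a methyl on the carbon that carries chloro in compound 3 would match chloro, or whether a chloro on the carbon that carries methyl in compound 2 would match methyl. On these data alone, it also remains open how this same carbon would respond to a quite different group, such as an amine, a carboxylic acid or a longer chain.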